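The compounds below may be only part of what the source reports. "The series", "measured", "known", "first", "only" and "open" are said of these compounds alone.

Compound 1 `O=S(=O)(CC1=NCCO1)C1C(c2ccc(Cl)cc2)=NOC1c1ccc(Cl)cc1` in a functional assay, tested at 100 ug/mL; on this read-out lower numbers stand for a weaker effect and higher numbers for a stronger effect at the one concentration tested: "not active" (no number reported).
Compound 2 `Cc1ccc(C2CNN=C2S(=O)(=O)CC2=NCCS2)cc1` in this assay: 45.1%.
Compound 3 `Cc1ccc(C2CNN=C2S(=O)(=O)CC2=NCCO2)cc1` in this assay: 46.8%.

Compound 2 and compound 3 share one core and differ in a single place: a group of 5 heavy atoms (3 carbon, 1 nitrogen, 1 sulfur; one five-membered non-aromatic ring with 2 hetero atoms) in place of a group of 5 heavy atoms (3 carbon, 1 nitrogen, 1 oxygen; one five-membered non-aromatic ring with 2 hetero atoms), on a saturated chain carbon bound to a sulfonyl sulfur. This change gives a number 1.7 percentage points lower from compound 3 to compound 2 (within the scatter), so the two compounds sit together in this assay. Compound 1 is built on another core; how the two cores differ is not broken down here, and for compound 1 no single number was reported, only that it showed no activity. Compound 4 `O=S(=O)(CC1=NCCS1)C1C(c2ccc(Cl)cc2)=NOC1c1ccc(Cl)cc1` arises from compound 1 by the same change: a group of 5 heavy atoms (3 carbon, 1 nitrogen, 1 sulfur; one five-membered non-aromatic ring with 2 hetero atoms) in place of a group of 5 heavy atoms (3 carbon, 1 nitrogen, 1 oxygen; one five-membered non-aromatic ring with 2 hetero atoms), on a saturated chain carbon bound to a sulfonyl sulfur. Because a number 1.7 percentage points lower from compound 3 to compound 2 (within the scatter) stayed within the scatter, the same change is expected to shift compound 1 little. Compound 4 is therefore expected to remain weak in this assay, estimated at 10%, between 0% and 30%.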

Compound 4, a percentage reported as activity, at one concentration (the size of the read-out at that concentration, not a potency): "not active" (no number reported)
Nothing numeric was reported for compound 4; no gap can be computed for the estimate.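

In this assay, for the compounds shown here, compound 1 and compound 4 both lack a number, so no step between them can be read. No other measurement shown bears on this result. The compounds shown leave open whether this ring swap changes activity on the core of compound 1.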